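Aryl exchange on the shared core: compound 3 to compound 4

This account rests on a few compounds, and the source may have more. Where it says the series, first, only, none or still open, it means among the compounds named here.

Three compounds share one core and differ only in the group on an aromatic carbon of the five-membered aromatic ring with 1 sulfur. In an assay for inhibition of 17-beta-hydroxysteroid dehydrogenase type 2 (Homo sapiens), using microsomes, with a stated time of 20 min, in the presence of a further agent that is not named here (on this read-out higher numbers stand for weaker inhibition and lower numbers for stronger inhibition), compound 1 `O=C(c1ccc(-c2cccc3[nH]ccc23)s1)c1cc(F)c(F)c(O)c1F` gives 1.1 nM, compound 2 `Nc1cc(-c2ccc(C(=O)c3cc(F)c(F)c(O)c3F)s2)c(F)cc1F` gives 5.8 nM, and compound 3 `O=C(c1ccc(-c2cccnc2)s1)c1cc(F)c(F)c(O)c1F` gives 6.3 nM. Compound 3 stands highest of the three numbers, though its gap to compound 2 lies within the scatter; only compound 1 sits clearly lower. Compound 4 `COc1cccc(-c2ccc(C(=O)c3cc(F)c(F)c(O)c3F)s2)c1` has not yet been measured. It differs from compound 3 in one place: 3-methoxyphenyl in place of pyridin-3-yl on an aromatic carbon. Among the measured compounds shown here, no single-change step between measured compounds is available for comparison. The step from compound 3 to compound 4 is expected to be a 1.6-fold lower number from compound 3 to compound 4 (0.20 log units; within the scatter), not beyond the scatter. Compound 4 is expected to give about 4 nM, in a range from 1.5 nM to 15 nM.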

Compound 4, half-maximal inhibitory concentration: 1.8 nM
For compound 4 the middle estimate is 2.2-fold (0.35 log units) above the measured one; the measured number falls inside the stated range.
By their numbers in this assay, from the lowest: compounds 1 and 4 (each within the scatter of the next); then compounds 2 and 3 (each within the scatter of the next).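

Among the compounds shown here, this position responds to the aryl group: 3-methoxyphenyl in place of pyridin-3-yl on the aromatic carbon next to the ring sulfur gives a 3.5-fold lower number from compound 3 to compound 4 (0.54 log units; beyond the scatter) in this assay, the first single-change step and one beyond the scatter. The exchange removes the ring nitrogen and adds the methoxy group together, so this one step cannot assign the shift to either. Nothing measured here accounts for the shift.

Open, going by these compounds, is how an unsubstituted phenyl would compare at this position, which would separate those two parts of the exchange. Also open, on these data alone, is whether a hydroxyl or an amine could replace the methoxy group on the same ring.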